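The source may hold more compounds than are shown below. What is called first, only, known or untested is meant among the compounds shown, and "the series" means these compounds.

Values so far in a functional assay on cells (Breast cancer cell line, Homo sapiens) for inhibition (on this read-out lower numbers stand for stronger inhibition of growth and higher numbers for weaker inhibition of growth), are these:
Compound 1 `CN1C/C(=C\c2cccs2)C(O)/C(=C/c2cccs2)C1` gives 84300 nM
Compound 2 `CN1C/C(=C\c2cccs2)C2=NN(C)C(c3cccs3)C2C1` gives 86000 nM
Compound 3 `Cc1ccc(/C=C2\CN(C)CC3C2=NN(c2ccccc2)C3c2ccc(C)cc2)cc1` gives > 100000 nM (a limit of the assay)

Compound 2 and compound 1 hold the only two true numbers among these, and they lie within the scatter of each other, so the two cannot be ranked.

Compound 4 `CN1C/C(=C\c2cccs2)C2=NN(c3ccccc3)C(c3cccs3)C2C1` has not yet been measured. It carries phenyl in place of methyl on an amine nitrogen in a ring of compound 2 (phenyl in place of methyl on an amine nitrogen in a ring) and keeps the rest of that structure. Compound 3 also has a phenyl in that place, and its reading of > 100000 nM is a limit of the assay and not a number. For the measured compounds named here, no measured pair shows this change on its own, so the basis for judging its size is thin. In this assay no step beyond the scatter is expected, with at most a slight drift toward weaker inhibition of growth. The estimated change is a 1.0-fold higher number from compound 2 to compound 4 (0.02 log units; within the scatter) and no more than that is expected. For compound 4 the estimated value is 90000 nM with an expected range from 40000 nM to 170000 nM and the reading may well come back as a limit only.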

Compound 4, concentration for 50% growth inhibition: 23600 nM
Beside the measured number, compound 4's estimate is 3.8-fold (0.58 log units) above it; measured number outside the range, below it.
By their numbers in this assay, from the lowest: compound 4; then compounds 1 and 2 (each within the scatter of the next). At a limit, above all of these: compound 3.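

Phenyl in place of methyl on an amine nitrogen in a ring gives the first step beyond the scatter among the compounds shown in this assay, a 3.6-fold lower number from compound 2 to compound 4 (0.56 log units; beyond the scatter). This place, next to the ring atom that bears a thiophen-2-yl group, therefore responds to what is attached there, with stronger inhibition of growth when phenyl rather than methyl sits on that nitrogen. Compound 3 also carries phenyl in that place, but it differs from compound 4 elsewhere as well and its reading is a limit of the assay, so it gives no second measure of this change: the limit of > 100000 nM in this assay, at which 1 of the 4 values shown sits.

From the compounds shown here alone, the change therefore rests on one pair, and it remains open whether phenyl would have the same effect with the other groups of compound 3 on the core. Going by these compounds, it also remains open how a benzyl group, a pyridyl group or a chlorophenyl group on this nitrogen would compare with phenyl, and whether any of them would move the number further in either direction.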